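Methoxy added to a sulfonamide-bearing pyrazole: cytotoxicity outlook

The source may hold more compounds than are shown below. What is called first, only, known or untested is meant among the compounds shown, and "the series" means these compounds.

Compound 3 `NS(=O)(=O)c1ccc(-n2nc(-c3ccccc3)cc2-c2ccc3cc(F)ccc3n2)cc1` gives 89.2% in an ADME assay on Huh-7 cells (Homo sapiens) for cytotoxicity, read by XTT assay, with a stated time of 3 days, tested at 20 uM; on this read-out lower numbers stand for a stronger effect and higher numbers for a weaker effect at the one concentration tested; its gap to compound 1 `COc1ccc(-c2cc(-c3ccc4cc(F)ccc4n3)n(-c3ccccc3)n2)cc1` at 104% is beyond the scatter, while its gap to compound 2 `COc1ccc(-c2cc(-c3ccc4cc(F)ccc4n3)n(-c3ccc(F)cc3)n2)cc1` at 98.8% is within it. Compound 4 `COc1ccc(-c2cc(-c3ccc4cc(F)ccc4n3)n(-c3ccc(S(N)(=O)=O)cc3)n2)cc1` carries methoxy in place of hydrogen on an aromatic carbon. Going by the values given here, the only measured single step, a number 5.2 percentage points lower from compound 1 to compound 2 (within the scatter), is a different change and stayed within the scatter; compounds 1 and 3, which differ in two places, show a larger gap, but no step for methoxy alone is known. The step of a number 0.8 percentage points higher from compound 3 to compound 4 (within the scatter) is therefore expected to stay within the scatter. Compound 4 is estimated at 90%, between 76% and 104% in this assay.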

Compound 4, a percentage reported as activity, at one concentration (the size of the read-out at that concentration, not a potency): 83.7%
Compound 4: middle estimate off by 6.3 percentage points, on the high side; low and high end bracket the measured number.
By their numbers in this assay, from the lowest: compounds 4, 3, 2 and 1 (each within the scatter of the next, the first and the last beyond it).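

In this assay, going by these compounds alone, methoxy in place of hydrogen on this aromatic carbon gives a number 5.5 percentage points lower from compound 3 to compound 4 (within the scatter), so this change, measured alone for the first time, does not move the reading beyond the usual variation. The sulfamoyl group now has single-change steps that do go beyond it: in place of hydrogen it gives a number 20.3 percentage points lower from compound 1 to compound 4 (beyond the scatter), and in place of fluoro it gives a number 15.1 percentage points lower from compound 2 to compound 4 (beyond the scatter). No measurement at hand explains these steps. As far as these compounds go, whether an amine or a carboxylic acid in place of the methoxy would read differently stays open.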